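The source may hold more compounds than are shown below. What is called first, only, known or untested is meant among the compounds shown, and "the series" means these compounds.

Measured in a functional assay on PC-3 cells (Homo sapiens) for cytotoxicity, read by MTT assay, with a stated time of 24 h; on this read-out lower numbers stand for stronger inhibition and higher numbers for weaker inhibition:

Compound 1, `O=C1/C(=C/c2ccccc2F)CN(Cc2cn(Cc3ccccc3F)nn2)C/C1=C\c1ccccc1F`, gives 19700 nM.
Compound 2, `O=C1/C(=C/c2ccccc2F)CN(Cc2cn(Cc3ccccc3Cl)nn2)C/C1=C\c1ccccc1F`, gives 7100 nM.
Compound 3, `Cc1ccc(/C=C2\CN(Cc3cn(Cc4ccccc4F)nn3)C/C(=C\c3ccc(C)cc3)C2=O)cc1`, gives 8800 nM.

Compound 1 and compound 2 share one core and differ in a single place: chloro in place of fluoro on an aromatic carbon. In this assay this step is a 2.8-fold lower number from compound 1 to compound 2 (0.44 log units; beyond the scatter). Compound 3 carries a different core; how its core differs from that of compound 1 is not broken down here. Compound 3 and compound 2 give values within the usual scatter of one another, so nothing can be said about their order, while compound 3 and compound 1 lie apart by more than the scatter, with compound 3 giving the lower number.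

Compound 4, `Cc1ccc(/C=C2\CN(Cc3cn(Cc4ccccc4Cl)nn3)C/C(=C\c3ccc(C)cc3)C2=O)cc1`, is not yet measured. It differs from compound 3 in a single place: chloro in place of fluoro on an aromatic carbon. The place wording is the same for both pairs, so this is the same change that turns compound 1 into compound 2, made on the core of compound 3. If it behaves as it did there, compound 4 is expected to give a number lower than compound 3, a step of about a 2.7-fold lower number from compound 3 to compound 4 (0.43 log units; beyond the scatter) in this assay, an expectation that rests on compound 1 and compound 2 showing a 2.8-fold lower number from compound 1 to compound 2 (0.44 log units; beyond the scatter). Among the compounds with values here, since only one earlier instance of the change exists, and on another core, the range is kept wide. Compound 4 is estimated at 3300 nM in this assay, expected to fall between 1400 nM and 8000 nM.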

Compound 4, half-maximal inhibitory concentration: 8900 nM
Estimate against measurement, compound 4: 2.7-fold (0.43 log units) below; the measured number lies above the stated range.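

In this assay, 2-chlorobenzyl in place of 2-fluorobenzyl on the core of compound 3 gives a 1.0-fold higher number from compound 3 to compound 4 (0.00 log units; within the scatter), so compound 3 and compound 4 cannot be put in any order. Set beside the earlier instance, the step read on the core of compound 1 does not carry over to the core of compound 3, and the two cores give different answers for the same exchange: the same change on two cores in this assay, a 2.8-fold lower number (0.44 log units; beyond the scatter) from compound 1 to compound 2 and a 1.0-fold higher number (0.00 log units; within the scatter) from compound 3 to compound 4, 2.8-fold (0.45 log units) apart, beyond the scatter of two such steps. This shows that, in this series, a step measured for chloro in place of fluoro on one core is not a safe guide to the same change on another, but with one pair per core it does not show which difference between the cores matters, nor does it give any cause for the gap.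

Left open is how a bromo or a methoxy group in that same place would read on each of the two cores, which would show whether the core dependence extends beyond this one exchange. Also open, going by these compounds, is whether a third core, for instance one carrying an amine or a carboxylic acid on its outer aromatic rings, would follow the pair compound 1 and compound 2 or the pair compound 3 and compound 4.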